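The compounds below may be only part of what the source reports. "The series", "measured", "known", "first", "only" and "open" are said of these compounds alone.

Series in a functional assay on U-251 cells (Homo sapiens) for inhibition, read by sulforhodamine B assay, with a stated time of 48 h; a higher number here means a weaker inhibitor of growth, a lower number a stronger inhibitor of growth:
- compound 1 `S=C(N/N=C/c1cccs1)Nc1ccccc1`: 74700 nM
- compound 2 `S=C(N/N=C/c1cccs1)Nc1cccnc1`: 26000 nM
- compound 3 `C=CCNC(=S)N/N=C/c1cccs1`: > 100000 nM

Compound 3 gives > 100000 nM, which is a limit of the assay and not a number. Of the two true numbers, compound 1 holds the higher, and compound 2 lies lower by a gap beyond the scatter. Compound 4 `S=C(N/N=C/c1cccs1)Nc1ccc(Br)cc1` carries bromo in place of hydrogen on an aromatic carbon, para to a large group (bromo in place of hydrogen on an aromatic carbon). For the measured compounds named here, no measured pair isolates this change. Going by the values given here, the only guide is that compound 2, with a different aromatic ring, stands at 26000 nM. A modest downward move is expected, estimated as a 2.1-fold lower number from compound 1 to compound 4 (0.33 log units; beyond the scatter). Compound 4 is expected at 35000 nM, with an estimated range of 12000 nM to 90000 nM.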

Compound 4, concentration for 50% growth inhibition: 4200 nM
Estimate against measurement, compound 4: 8.3-fold (0.92 log units) above; measured number outside the range, below it.
By their numbers in this assay, from the lowest: compound 4; then compound 2; then compound 1. At a limit, above all of these: compound 3.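

In this assay, the step for bromo in place of hydrogen on an aromatic carbon, para to a large group, is an 18-fold lower number from compound 1 to compound 4 (1.25 log units; beyond the scatter). For the compounds shown here, the earlier compounds carried no substituent on this ring, so this is the first sign that this position accepts a group and that a single bromine atom there strengthens growth inhibition markedly. Nothing given here accounts for the size of this step.

Going by these compounds, whether the step is specific to bromo remains open; chloro, methoxy or an amine at this position would test that. Bromo at another carbon of this ring would show whether the position itself matters.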